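This account rests on a few compounds, and the source may have more. Where it says the series, first, only, none or still open, it means among the compounds named here.

Working notes on the amide series built on the shared core of compound 1 `CCC(=O)N1CC2CC(C1)N2`. In an assay on CHO cells for agonist activity at Neuronal acetylcholine receptor; alpha3/alpha6/beta2/beta3 (Homo sapiens), read by FLIPR and calcium flux (a lower number here means a smaller maximal response, a higher number a larger maximal response), compound 1 gives 120%, the highest of the three numbers in hand. Compound 2 `CC(C)C(=O)N1CC2CC(C1)N2`, carrying methyl in place of hydrogen on a saturated chain carbon bound to a carbonyl carbon and a saturated chain carbon, gives 45% in this assay, a drop recorded as a number 75 percentage points lower from compound 1 to compound 2 (beyond the scatter). Compound 3 `O=C(C1CCC1)N1CC2CC(C1)N2`, with cyclobutyl in place of ethyl on the carbonyl carbon, gives 80% in this assay, and the step from compound 1 is a number 40 percentage points lower from compound 1 to compound 3 (beyond the scatter); between the two ring and branch variants the step runs a number 35 percentage points higher from compound 2 to compound 3 (beyond the scatter).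

Compound 4 `O=C(CC1C=CCC1)N1CC2CC(C1)N2` is the next member, not yet measured. Against compound 1 the change is cyclopent-2-en-1-yl in place of methyl on a saturated chain carbon bound to a carbonyl carbon. Both measured steps away from compound 1 lowered the maximal response, the larger one for added bulk on the saturated chain carbon bound to the carbonyl, the smaller one for a ring on the carbonyl carbon. Within the data shown here, compound 4 adds a considerably larger group at the first of these places, so a decrease beyond the scatter is expected, though the scale is uncertain since no measured step matches this change closely. The expected step for compound 4 is a number 60 percentage points lower from compound 1 to compound 4 (beyond the scatter). Compound 4 is therefore estimated at 60% in this assay, with a range from 25% to 100%.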

Compound 4, largest response reached (Emax), in percent of the reference or control that the assay uses: 47%
For compound 4 the middle estimate is 13 percentage points above the measured one; low and high end bracket the measured number.
By their numbers in this assay, from the lowest: compounds 2 and 4 (each within the scatter of the next); then compound 3; then compound 1.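

In this assay, placing cyclopent-2-en-1-yl in place of methyl on a saturated chain carbon bound to a carbonyl carbon gives a number 73 percentage points lower from compound 1 to compound 4 (beyond the scatter), so a ring with a double bond outside aromatic rings at this place also leaves the maximal response well under that of the parent amide. The new point is that the response does not keep falling with the size of the entering group: compound 2 at 45% and compound 4 at 47% lie within the scatter of each other, although the group in compound 4 brings five carbons and a ring, so among these compounds any addition on this carbon gives a similar low response. No measured data bear on why the response falls at this place, and no reason can be assigned from these numbers.

The compounds shown leave open whether the double bond matters, since cyclopentyl, its saturated counterpart, would separate the ring from the double bond at this place. They also leave open whether phenyl or an amine on the same carbon would hold the response at this low level or restore it towards that of compound 1.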